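From fluoro to bromo on a shared core

This account rests on a few compounds, and the source may have more. Where it says the series, first, only, none or still open, it means among the compounds named here.

Compound 1 `CCC(=O)N(c1ccc(OC)cc1)C1CCCC1N(C)C`: 20 mg/kg; 20 mg/kg (2 entries)
Compound 2 `CCC(=O)N(c1ccc(C)cc1)C1CCCC1N(C)C`: 10 mg/kg; 10 mg/kg (2 entries)
Compound 3 `CCC(=O)N(c1ccc(F)cc1)C1CCCC1N(C)C`: 0.08 mg/kg

In a functional assay on the whole organism for antagonist activity, with Mus musculus as the target (on this read-out higher numbers stand for an effect only at larger amounts of compound and lower numbers for an effect already at smaller amounts), compound 3 gives 0.08 mg/kg, a far smaller number than those of compound 1 and compound 2, whose own values lie within the usual scatter of each other. Among the compounds with values here, compound 3 has only this one number, and two further entries for it give no single number, so its position is less firmly fixed than it looks.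

Compound 4 `CCC(=O)N(c1ccc(Br)cc1)C1CCCC1N(C)C` departs from compound 3 in one place: bromo in place of fluoro on an aromatic carbon. Within the data shown here, no measured pair shows this exchange, so there is no direct step to copy. Among the measured compounds shown here, the only guide is that compound 2, at 10 mg/kg; 10 mg/kg (2 entries), and compound 1, at 20 mg/kg; 20 mg/kg (2 entries), both carry other groups in that place and need much larger doses. A clear rise beyond the scatter in this assay is therefore expected, with a 25-fold higher number from compound 3 to compound 4 (1.40 log units; beyond the scatter) as the estimated step. The estimate for compound 4 is 2 mg/kg, with an expected range from 0.2 mg/kg to 20 mg/kg.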

Compound 4, dose for half-maximal effect: 3 mg/kg
The estimate for compound 4 lay 1.5-fold (0.18 log units) below the measured number; the range from low to high includes it.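

In this assay, within the data shown here, bromo in place of fluoro on the aromatic carbon gives a 38-fold higher number from compound 3 to compound 4 (1.57 log units; beyond the scatter), the first step at this place that can be read directly from a measured pair. The two groups match in what is counted here: each is a single heavy atom, with no hydrogen-bond donors or acceptors and no net charge. The dose needed can therefore shift widely even when those counts stay the same, although nothing available explains the size of this step.

As far as these compounds go, what a chloro, a hydroxyl or an amine at this place would give remains open, so it cannot be said how the dose changes across the halogens. The size of the step also rests on a single number for compound 3, whose two further entries give no single value.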